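Cyclohexyl for 4-Propylphenyl on Two Related Cores

A few compounds are considered here, and "the series" means these few. Any claim that something is new, unique, unknown or untested is made for them only; others in the source may bear on it.

compound 1 `CCCc1ccc(NC2=CC(=O)c3nc4n(c3C2=O)[C@H]2OC[C@@H](O)[C@H]2OC4)cc1` in a functional assay on MCF7 cells (Homo sapiens) for inhibition, read by sulforhodamine B assay (a lower number here means a stronger inhibitor, a higher number a weaker inhibitor), gives 4660 nM
compound 2 `O=C1C=C(NC2CCCCC2)C(=O)c2c1nc1n2[C@H]2OC[C@@H](O)[C@H]2OC1` gives > 8000 nM, a limit of the assay
compound 3 `CCCc1ccc(NC2=CC(=O)c3c(nc4n3[C@H]3OC[C@@H](O)[C@H]3OC4)C2=O)cc1` gives > 4000 nM, a limit of the assay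

Compounds 1 and 3 are built from the same atoms joined differently; the difference between the two cores is not broken down here. From compound 1 to compound 2 the change is cyclohexyl in place of 4-propylphenyl on an amine nitrogen, and it gives an at least 1.7-fold higher number from compound 1 to compound 2 (0.23 log units; that floor lies within the scatter); the reading for compound 2 is a limit, (the limit of > 8000 nM in this assay, at which 1 of the 3 values shown sits). Compound 4 `O=C1C(NC2CCCCC2)=CC(=O)c2c1nc1n2[C@H]2OC[C@@H](O)[C@H]2OC1` makes the same change on the core of compound 3: cyclohexyl in place of 4-propylphenyl on an amine nitrogen. Compound 3 itself gives only a limit, (the limit of > 4000 nM in this assay, at which 1 of the 3 values shown sits). The expected step is estimated as a step that the limit leaves unreadable from compound 3 to compound 4, resting on the measured step of an at least 1.7-fold higher number from compound 1 to compound 2 (0.23 log units; that floor lies within the scatter) and on the limit for compound 3 (the limit of > 4000 nM in this assay, at which 1 of the 3 values shown sits). Compound 4 is therefore expected to give 10000 nM in this assay, most likely reported again as a limit only.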

Compound 4, half-maximal inhibitory concentration: > 16000 nM
Compound 4 was reported as a limit (the forecaster's own chance of this, stated with the estimate: 80%); middle value at least 1.6-fold (0.20 log units) from the limit.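

Compound 3 and compound 4 are both reported only as limits, so the step between them cannot be read. The compounds shown leave open whether cyclohexyl in place of 4-propylphenyl acts alike on the two cores.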